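The compounds below may be only part of what the source reports. "The series", "measured", "known", "first", "only" and "open" are said of these compounds alone.

Measured compounds:
compound 1, `Cc1ccc(OCc2cn(-c3ccc(S(=O)(=O)N4CCc5ccccc5C4)cc3)nn2)cc1`: > 50 ug/mL
compound 2, `COc1cc2c(cc1OC)CN(S(=O)(=O)c1ccc(-n3cc(COc4ccc(C=O)cc4)nn3)cc1)CC2`: > 50 ug/mL

In an ADME assay on Vero cells (Chlorocebus sabaeus) for cytotoxicity, with a stated time of 4 days (a lower number here means a stronger inhibitor, a higher number a weaker inhibitor), compound 1 gives > 50 ug/mL, which is a limit of the assay rather than a number. In this assay compound 2 gives > 50 ug/mL, also a limit. Where compound 1 stands can therefore only be said loosely: its own value is a limit, and the one further value shown is a limit as well, so both sit at the limit of > 50 ug/mL in this assay, at which 2 of the 2 values shown sit.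

Compound 3, `O=S(=O)(c1ccc(-n2cc(COc3ccc4ccccc4c3)nn2)cc1)N1CCc2ccccc2C1`, has not yet been measured in this assay. It differs from compound 1 in one place: naphthalen-2-yl in place of 4-methylphenyl on an oxygen on a saturated carbon. Within the data shown here, no step between two measured compounds is known here, so the size of this change cannot be read from any earlier pair. Among the measured compounds shown here, because the only evidence is the limit of > 50 ug/mL in this assay, at which 2 of the 2 values shown sit, the expectation is that the step of a number no higher from compound 1 to compound 3 (the limit leaves the size open) will be none beyond the scatter. Compound 3 is accordingly expected to give 50 ug/mL in this assay, with a range from 20 ug/mL to 120 ug/mL, and most likely it will again be reported only as a limit.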

Compound 3, half-maximal inhibitory concentration: > 50 ug/mL
Compound 3: a limit, no number (the forecaster's own chance of this, stated with the estimate: 70%); the middle value sits exactly at the limit.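

In this assay compound 3 gives > 50 ug/mL, which is a limit of the assay and not a number. Compound 1 gives > 50 ug/mL, also a limit, so the step from compound 1 to compound 3, naphthalen-2-yl in place of 4-methylphenyl, cannot be read. The compounds shown leave open whether any change to this series gives a true number in this assay.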